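The compounds below may be only part of what the source reports. "The series", "measured", "known", "first", "only" and "open" are said of these compounds alone.

Compounds measured so far:
compound 1, `COc1cc(Cn2cc(COc3cccc(/C=C4\C(=O)Nc5ccccc54)c3)nn2)cc(OC)c1`: > 50000 nM
compound 2, `O=C1Nc2ccc(Cl)cc2/C1=C/c1cccc(OCc2cn(Cc3ccccc3)nn2)c1`: no result reported

In a functional assay on BT-549 cells (Homo sapiens) for inhibition, read by MTT assay, with a stated time of 48 h (a higher number here means a weaker inhibitor, a lower number a stronger inhibitor), compound 1 reaches only a limit of the assay, > 50000 nM, which is the limit of > 50000 nM in this assay, at which 1 of the 2 values shown sits. For compound 2 this assay gives "not determined" (no result reported), so compound 2 stands on no number at all. Compound 3, `O=C1Nc2ccc(Br)cc2/C1=C/c1cccc(OCc2cn(Cc3ccccc3)nn2)c1`, differs from compound 2 by bromo in place of chloro on an aromatic carbon. For the measured compounds named here, with no measured step to rest on, only a change in this assay within the usual scatter is expected from this exchange. Compound 3 is estimated at 20000 nM, between 2000 nM and 50000 nM.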

Compound 3, half-maximal inhibitory concentration: > 50000 nM
Compound 3: only a limit was reported; the forecaster's own chance of this, stated with the estimate: 45%; middle value at least 2.5-fold (0.39 log units) from the limit.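

In this assay compound 3 reaches only a limit, > 50000 nM. With no result reported for compound 2, no step can be read between compound 2 and compound 3. The compounds shown leave open whether exchanging chloro for bromo changes inhibition at all.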